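Removing a methoxy group from a pyrazoline naphthol series

A few compounds are considered here, and "the series" means these few. Any claim that something is new, unique, unknown or untested is made for them only; others in the source may bear on it.

Four compounds from one series are considered here, all of which carry a naphthol attached to a pyrazoline ring and differ in the substitution of a second aromatic ring. Compound 1 `COc1ccc(C2CC(c3c(O)ccc4ccccc34)=NN2c2ccc(Cl)cc2)c(OC)c1` and compound 2 `COc1cc(OC)c(C2CC(c3c(O)ccc4ccccc34)=NN2c2ccc(Cl)cc2)cc1OC` share a chlorophenyl group on the pyrazoline nitrogen, whereas compound 3 `COc1cccc(C2CC(c3ccc4ccccc4c3O)=NN2)c1OC` and compound 4 `COc1ccccc1C1CC(c2ccc3ccccc3c2O)=NN1` do not. In a functional assay on HCT-116 cells (Homo sapiens) for cytotoxicity, read by crystal violet staining and colony formation, with a stated time of 7 days (a higher number here means a weaker inhibitor, a lower number a stronger inhibitor), compound 1 gives 5400 nM and compound 2 gives 7800 nM. The step of a 1.4-fold lower number from compound 2 to compound 1 (0.16 log units; within the scatter) comes from one change, (hydrogen in place of methoxy on an aromatic carbon). Compound 3 gives 15200 nM in this assay; its value lies beyond the scatter of compound 1 but within the scatter of compound 2. The difference between the cores of compound 3 and compound 2 is not broken down here.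

Compound 4, which is not yet measured, differs from compound 3 by hydrogen in place of methoxy on an aromatic carbon. This is the same kind of change as that from compound 2 to compound 1, but not the same: in compound 2 the position is also para to a methoxy group, while in compound 3 it is not, and the cores differ as well. Because the step of a 1.4-fold lower number from compound 2 to compound 1 (0.16 log units; within the scatter) stayed within the scatter, the estimate for compound 4 in this assay is a similarly small step, a 1.4-fold lower number from compound 3 to compound 4 (0.14 log units; within the scatter). Compound 4 is thus expected to give about 11000 nM, with a likely range from 5000 nM to 25000 nM.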

Compound 4, half-maximal inhibitory concentration: 17400 nM
For compound 4 the middle estimate is 1.6-fold (0.20 log units) below the measured one, within the range that was stated.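

In this assay, taking the methoxy group off the core of compound 3 gives a 1.1-fold higher number from compound 3 to compound 4 (0.06 log units; within the scatter), so this second case of the change also leaves the number within the scatter. Set beside the earlier case, the change shows no detectable difference between the two cores: the same change on two cores in this assay, a 1.4-fold lower number (0.16 log units; within the scatter) from compound 2 to compound 1 and a 1.1-fold higher number (0.06 log units; within the scatter) from compound 3 to compound 4, 1.7-fold (0.22 log units) apart, within the scatter of two such steps This shows that, in these two pairs, hydrogen in place of methoxy on an aromatic carbon leaves cytotoxicity in this assay essentially unmoved on both cores, but it does not show that the change is neutral across the series, and with neither step beyond the scatter, no direction can be assigned to either step and the carrying over of a clear effect from one core to the other remains untested.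

As far as these compounds go, whether an amine, a carboxylic acid or a longer alkoxy chain in the same place would move the number beyond the scatter remains open. Also open is what the chlorophenyl group on the pyrazoline nitrogen contributes, as no pair shown differs in that place alone.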